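Methyl for phenyl on the shared core

The compounds below may be only part of what the source reports. "The series", "measured", "known", "first", "only" and "open" are said of these compounds alone.

Measured compounds:
compound 1, `Cc1c(-c2ccccc2)c(N2CC[C@H](N(C)C)C2)n2nc(C(C)(C)COCc3ccccc3)nc2c1C#N`, 3.8 in a physicochemical assay for lipophilicity, in phosphate buffer, measured as octanol-water partition, at pH 6.8; a higher number here means a more lipophilic compound, a lower number a more polar compound;
compound 2, `Cc1c(-c2ccccc2)c(N2CC[C@H](N(C)C)C2)n2nc(-c3ccccc3)nc2c1C#N`, "not determined" (no result reported) in this assay.

Compound 2 stands without a number here: in this assay no value for it was reported, so its place among the measured compounds is open. Among the compounds with values here, compound 1 is the only one with a value, and in this assay compound 1 gives 3.8.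

Compound 3, `Cc1nc2c(C#N)c(C)c(-c3ccccc3)c(N3CC[C@H](N(C)C)C3)n2n1`, follows from compound 2 by one change: methyl in place of phenyl on an aromatic carbon. Within the data shown here, no pair of measured compounds shows this step, so its size is not known from the data. The expectation for compound 3 is a step downward in this assay relative to what compound 2 would have shown, by more than the usual scatter, since the group that leaves is larger than the one that enters. Compound 3 is therefore estimated at 2.3, with a range from 1.5 to 3.1.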

Compound 3, distribution coefficient: 1.7
Beside the measured number, compound 3's estimate is 0.60 log units above it; measured number inside the range.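

Within the data shown here, with compound 3, the group on this aromatic carbon, between two ring nitrogen atoms, can for the first time be read as a single change in this assay. Putting methyl in place of 1-((benzyloxy)methyl)-1-methylethyl gives a number 2.10 log units lower from compound 1 to compound 3 (beyond the scatter), so the choice of group at this one place, with the rest of the shared core unchanged, is enough to move the read-out well beyond the scatter. Nothing presented here accounts for the size of this step.

On these data alone, the step to compound 3 from compound 2 cannot be read, as compound 2 has no number, so where phenyl falls on this scale stays open. Also open, as far as these compounds go, is how a primary amine, a carboxylic acid or a plain propyl chain at this carbon would read in this assay.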